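Replacing diethylamino with methoxy: notes on compound 4

The source may report more compounds than this note shows. Statements on the series, on what has been measured and on what is new or still open speak of the compounds shown alone.

Measured in a functional assay on SW620/5-FU cells (Homo sapiens) for cytotoxicity, read by MTT assay, with a stated time of 48 h, in the presence of a further agent that is not named here; a higher number here means that more compound is needed for the effect, a lower number that less compound is needed:
- compound 1 `Cn1ncc2c(-c3ccc(F)cc3)cc(NNC(=O)Nc3cc(Cl)nc(OCCF)c3)nc21`: 29300 nM
- compound 2 `CCN(CC)c1cc(NC(=O)NNc2cc(-c3ccc(F)cc3)c3cnn(C)c3n2)cc(Cl)n1`: 37000 nM
- compound 3 `Cc1nn(C)c2nc(NNC(=O)Nc3cc(Cl)nc(Cl)c3)cc(-c3ccco3)c12`: a limit of the assay, > 100000 nM, the same limit described by the limit of > 100000 nM in this assay, at which 1 of the 3 values shown sits.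

Compound 2 stands at the highest of the two numbers shown, and its nearest neighbour is compound 1, since a 1.3-fold higher number from compound 1 to compound 2 (0.10 log units; within the scatter). That step is therefore within the scatter, so compound 1 and compound 2 are not distinguished on the data given.

Compound 4 `COc1cc(NC(=O)NNc2cc(-c3ccc(F)cc3)c3cnn(C)c3n2)cc(Cl)n1` is not yet measured. It differs from compound 2 in one place: methoxy in place of diethylamino on an aromatic carbon.

Among the compounds with values here, the only measured step bears directly on this change, as it alters the same group on the same aromatic carbon: the exchange of 2-fluoroethoxy for diethylamino gave a 1.3-fold higher number from compound 1 to compound 2 (0.10 log units; within the scatter). A second exchange at that position, now to methoxy, is therefore expected to move the number by no more than the scatter, with no direction favoured. The expected step is a 1.2-fold lower number from compound 2 to compound 4 (0.06 log units; within the scatter).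

Compound 4 is accordingly estimated at 32000 nM in this assay, with a range from 12000 nM to 85000 nM.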

Compound 4, half-maximal effective concentration: 24100 nM
The estimate for compound 4 lay 1.3-fold (0.12 log units) above the measured number; the measured number falls inside the stated range.
By their numbers in this assay, from the lowest: compounds 4, 1 and 2 (each within the scatter of the next). At a limit, above all of these: compound 3.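

In this assay, the exchange of diethylamino for methoxy gives a 1.5-fold lower number from compound 2 to compound 4 (0.19 log units; within the scatter), and shortening the 2-fluoroethoxy chain to methoxy gives a 1.2-fold lower number from compound 1 to compound 4 (0.08 log units; within the scatter). Both steps stay within the scatter, so all three groups now read at this position, on the aromatic carbon next to the ring nitrogen, remain undistinguished, even with the drop from 5 heavy atoms in diethylamino to 2 in methoxy and with oxygen replacing nitrogen as the attached atom. The position therefore tolerates these exchanges without a resolved change in the number, though nothing in the data at hand accounts for this.

On these data alone, what remains open is whether any group at this position can move the number beyond the scatter, for example a carboxylic acid, a primary amine or a morpholine ring. As far as these compounds go, the chloro group is also constant across the compounds compared here, so it is unknown whether this position would read the same with a nitrile in its place.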